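A few compounds are considered here, and "the series" means these few. Any claim that something is new, unique, unknown or untested is made for them only; others in the source may bear on it.

Three compounds have been measured in a functional assay for binding affinity to metabotropic glutamate receptor 2 (Homo sapiens), read by GTPgammaS binding, with a stated time of 1 h, at 30 degrees C; a higher number here means that more compound is needed for the effect, a lower number that less compound is needed:

Compound 1 `CCCc1c(OCCCCOc2ccc(-c3nn[nH]n3)cc2)ccc2c1ccn2CC(C)(C)C`, which in this assay gives 559 nM.
Compound 2 `CCCc1c(OCCCCOc2ccc(-c3nn[nH]n3)cc2)ccc2c1cnn2CC(C)(C)C`, which in this assay gives 984 nM.
Compound 3 `CCCc1c(OCCCCOc2ccc(-c3nn[nH]n3)cc2)ccc2c1nnn2CC(C)(C)C`, which in this assay gives 188 nM.

Compound 1 stands with the second highest of the three numbers. Its value and that of compound 2 lie within the usual scatter of each other, so nothing can be read into the gap between them. Compound 3, whose number is lower than that of compound 1 by a margin beyond the scatter, is the one of the three that needs the least compound for the effect. For the measured compounds named here, the three differ only in their shared core, and no single-point step between them has been counted.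

Compound 4 `CCCc1c(OCCCCOc2ccc(-c3nn[nH]n3)cc2)ccc2c1ccn2CC(C)C` keeps the core of compound 1 and differs from it at the chain on the ring nitrogen: hydrogen in place of methyl on a saturated chain carbon bound to three saturated chain carbons. Going by the values given here, no measured pair shows this change, so its size is not known from the data. A change of this kind, at a position away from the ring systems, is expected to give no step beyond the scatter. The step from compound 1 to compound 4 is estimated as a 1.2-fold higher number from compound 1 to compound 4 (0.07 log units; within the scatter), and compound 4 is expected to give about 650 nM, with a range from 280 nM to 1500 nM.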

Compound 4, half-maximal effective concentration: 765 nM
Beside the measured number, compound 4's estimate is 1.2-fold (0.07 log units) below it; measured number inside the range.
By their numbers in this assay, from the lowest: compound 3; then compounds 1, 4 and 2 (each within the scatter of the next).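

In this assay, for the compounds shown here, the change from neopentyl to isobutyl gives a 1.4-fold higher number from compound 1 to compound 4 (0.14 log units; within the scatter), the first step in this set that can be read at a single place. Going by these compounds alone, it shows that, on the core of compound 1, hydrogen in place of methyl on a saturated chain carbon bound to three saturated chain carbons does not move the number beyond the scatter, something the earlier compounds could not show, as they differ only in their shared core. Nothing measured here speaks to why this chain change leaves the number within the scatter.

The compounds shown leave open whether the same change would also stay within the scatter on the core of compound 3, which has the lowest number of the set. They also leave open how far this chain can be altered, since the step covers only the loss of one methyl and says nothing about a plain ethyl, a longer chain such as n-hexyl, a cyclohexylmethyl group, or a chain ending in an amine or a carboxylic acid.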